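Shortening the carboxylic acid chain

The source may hold more compounds than are shown below. What is called first, only, known or untested is meant among the compounds shown, and "the series" means these compounds.

Measured in a functional assay on the whole organism (strain Wistar) for inhibition, with Rattus norvegicus as the target, read by paw edema, with stated times of 30 min and 3 h; on this read-out lower numbers stand for an effect already at smaller amounts and higher numbers for an effect only at larger amounts of compound:
Compound 1 `COc1cc(CCO)cc(-c2ccc(Cl)cc2)c1`: 47 mg/kg
Compound 2 `COc1cc(CCC(=O)O)cc(-c2ccc(Cl)cc2)c1`: > 100 mg/kg

Compound 2 stands at the limit of > 100 mg/kg in this assay, at which 1 of the 2 values shown sits, so its reading is a limit and not a number. Compound 3 `COc1cc(C(=O)O)cc(-c2ccc(Cl)cc2)c1` differs from it by carboxy in place of 2-carboxyethyl on an aromatic carbon, which is carboxy in place of 2-carboxyethyl on an aromatic carbon. Within the data shown here, only one measured step bears on this change: an at least 2.1-fold higher number from compound 1 to compound 2 (0.32 log units; beyond the scatter), which brought in the carboxy group and went beyond the scatter toward larger doses. Compound 3 keeps a carboxy group, so after that step no return toward compound 1 is expected, and no change clearly beyond the scatter is expected in this assay. The estimated step is a step that the limit leaves unreadable from compound 2 to compound 3. For compound 3 the expected value is 110 mg/kg, with an estimated range from 45 mg/kg to 280 mg/kg, and it may well be reported only as a limit.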

Compound 3, dose for half-maximal effect: > 100 mg/kg
Compound 3: a limit, no number (the forecaster's own chance of this, stated with the estimate: 60%); the middle value does not contradict the limit.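

Compound 3 gives > 100 mg/kg in this assay, and this too is a limit of the assay and not a number. Carboxy in place of 2-hydroxyethyl on the aromatic carbon gives an at least 2.1-fold higher number from compound 1 to compound 3 (0.32 log units; beyond the scatter), so with the chain removed as well as with the 2-carboxyethyl group, the carboxylic acids stay on the side of larger doses relative to the alcohol. The step from compound 2 to compound 3 cannot be read, because both readings are limits: the limit of > 100 mg/kg in this assay, at which 2 of the 3 values shown sit.

Going by these compounds, how far either acid lies past this limit stays open, and with it whether the length of the chain carrying the carboxy group matters at all. Also open, on these data alone, is whether a primary amide or a methyl ester in place of the carboxy group, or a shorter hydroxymethyl chain, would come back toward compound 1.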